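Swapping Phenyl for Pyridin-4-yl in a Chemokine Receptor Ligand

This account rests on a few compounds, and the source may have more. Where it says the series, first, only, none or still open, it means among the compounds named here.

Measured so far:
Compound 1, `O=C(NCc1ccc(CNS(=O)(=O)c2ccccc2)cc1)c1cccc(Cl)c1`, gives 1000 nM in an assay on MDA-MB-231 cells for binding affinity to C-X-C chemokine receptor type 4 (Homo sapiens), read by immunofluorescence and microscopy, with stated times of 10 min and 30 min; a lower number here means that less compound is needed, a higher number that more compound is needed for the effect.
Compound 2, `O=C(NCc1ccc(CNS(=O)(=O)c2ccccc2)cc1)c1ccccc1`, gives 1 nM in this assay.

Within the data shown here, compound 2 holds the lowest number of the two measured; its nearest neighbour is compound 1, and the only measured step, a 1000-fold lower number from compound 1 to compound 2 (3.00 log units; beyond the scatter), separates them. That step concerns hydrogen in place of chloro on an aromatic carbon of the shared core, and nothing else.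

Compound 3, `O=C(NCc1ccc(CNS(=O)(=O)c2ccccc2)cc1)c1ccncc1`, is not yet measured. It differs from compound 2 in a single place: pyridin-4-yl in place of phenyl on a carbonyl carbon. Among the measured compounds shown here, no measured step touches the carbonyl-bound ring itself, so the large step from compound 1 to compound 2 does not bear directly on this exchange; it only shows that the number in this assay can move far on a single change to the core. Without a directly comparable step, the expectation for compound 3 is a modest rise in the number, wider in range than usual. Compound 3 is thus estimated at 3 nM, within 0.5 nM to 30 nM, an expected step of a 3.0-fold higher number from compound 2 to compound 3 (0.48 log units; beyond the scatter).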

Compound 3, effective concentration (reported as EC, without a stated level of effect): 10 nM
Compound 3: middle estimate off by 3.3-fold (0.52 log units), on the low side; the range from low to high includes it.
By their numbers in this assay, from the lowest: compound 2; then compound 3; then compound 1.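

The carbonyl-bound ring turns out to respond to an exchange of the ring itself, and not only to the loss of a chloro group from it: in this assay, pyridin-4-yl in place of phenyl on a carbonyl carbon gives (a 10-fold higher number from compound 2 to compound 3 (1.00 log units; beyond the scatter)). That exchange keeps the count of heavy atoms and adds one ring nitrogen and one hydrogen-bond acceptor, yet compound 2, with its unsubstituted phenyl, still holds the lowest number of the three, while pyridin-4-yl in place of 3-chlorophenyl gives (a 100-fold lower number from compound 1 to compound 3 (2.00 log units; beyond the scatter)), which places compound 3 between the other two. Nothing at hand explains why either exchange moves the number as it does.

The three compounds leave open whether this position would accept other groups on the phenyl ring, such as a fluoro group, a methoxy group, an amine or a carboxylic acid, and whether the large step seen with chloro is particular to that atom. They also leave open how the number responds to changes elsewhere in the shared core, which stays the same in all three compounds.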